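The source may report more compounds than this note shows. Statements on the series, on what has been measured and on what is new or still open speak of the compounds shown alone.

Of the compounds shown here, three have been measured in an assay on isolated protein (Oryctolagus cuniculus) for inhibition of Calpain-2 catalytic subunit (Homo sapiens), at pH 8.0; a higher number here means a weaker inhibitor, a lower number a stronger inhibitor. Compound 1 `CCCCOC(=O)C(=O)C(CC)NC(=O)C(CC(C)C)NC(=O)OCc1ccccc1` gives 400 nM. Compound 2 `CCOC(=O)C(=O)C(CC)NC(=O)C(CC(C)C)NC(=O)CCCCc1ccccc1` gives 1900 nM. Compound 3 `CCOC(=O)C(=O)[C@H](CC)NC(=O)[C@H](CC(C)C)NC(=O)[C@H](CC(C)C)NC(=O)c1ccc2ccccc2c1` gives 90 nM. Among these numbers compound 1 stands second highest, with compound 3 the nearest and compound 2 the furthest from it. Compound 4 `CCC(NC(=O)C(CC(C)C)NC(=O)OCc1ccccc1)C(=O)C(=O)NCC1CCCCC1` has not yet been measured. It differs from compound 1 in one place: (cyclohexylmethyl)amino in place of butoxy on a carbonyl carbon. Within the data shown here, no measured pair shows this same change, so its size is uncertain. The expectation is a modest move towards stronger inhibition, a 2.7-fold lower number from compound 1 to compound 4 (0.43 log units; beyond the scatter), which may or may not lie beyond the scatter. Compound 4 is therefore expected to give about 150 nM in this assay, within a range from 40 nM to 600 nM.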

Compound 4, inhibition constant: 44 nM
Beside the measured number, compound 4's estimate is 3.4-fold (0.53 log units) above it, and the stated range covers the measured number.
By their numbers in this assay, from the lowest: compound 4; then compound 3; then compound 1; then compound 2.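

Putting (cyclohexylmethyl)amino in place of butoxy on this carbonyl carbon gives a 9.1-fold lower number from compound 1 to compound 4 (0.96 log units; beyond the scatter) in this assay, so inhibition clearly responds to the group at this position. The change brings in a six-membered ring of carbon only and a hydrogen-bond donor together, and this single step cannot separate the two. Nothing here explains the drop in the number. Still open, from the compounds shown here alone, is how much comes from the ring and how much from the amino nitrogen. A simple methylamino or a benzylamino at this position would help to tell them apart.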